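A few compounds are considered here, and "the series" means these few. Any claim that something is new, unique, unknown or untested is made for them only; others in the source may bear on it.

Compound 1 (`Cc1ccc(-c2cc(C(=O)Nc3cccnc3)c3cc(Br)ccc3n2)cc1`) – 21000 nM
Compound 2 (`Cc1ccc(-c2cc(C(=O)Nc3cccnc3)c3cc(F)ccc3n2)cc1`) – 50000 nM

In an ADME assay on MRC5 cells (Homo sapiens) for antiproliferative activity, read by fluorescence and resazurin assay, with a stated time of 68 h (a higher number here means that more compound is needed for the effect, a lower number that less compound is needed), compound 2 has the higher number of the two (50000 nM). Compound 3 (`Cc1ccc(-c2cc(C(=O)Nc3cccnc3)c3ccccc3n2)cc1`) has hydrogen in place of fluoro on an aromatic carbon. For the measured compounds named here, the only measured step at that carbon, fluoro in place of bromo (a 2.4-fold higher number from compound 1 to compound 2 (0.38 log units; beyond the scatter)), was modest, and no measured compound yet carries hydrogen there. That single step gives no firm direction, so in this assay no step beyond the scatter is expected, and the estimated step is small (a 1.2-fold lower number from compound 2 to compound 3 (0.08 log units; within the scatter)). Compound 3 is expected at 42000 nM (estimated range 18000 nM to 90000 nM).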

Compound 3, half-maximal effective concentration: > 50000 nM
Compound 3: a limit, no number (the forecaster's own chance of this, stated with the estimate: 20%); middle value at least 1.1-fold (0.07 log units) away from the limit.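

In this assay, compound 3 gives > 50000 nM, a limit of the assay and not a number: the limit of > 50000 nM in this assay, at which 1 of the 3 values shown sits.

Replacing bromo with plain hydrogen gives an at least 2.3-fold higher number from compound 1 to compound 3 (0.37 log units; beyond the scatter), so at this aromatic carbon bromo now stands apart from both fluoro and hydrogen, not only from fluoro. Replacing fluoro with hydrogen gives a number no lower from compound 2 to compound 3 (the limit leaves the size open); the size of this step cannot be read, so fluoro and hydrogen cannot be placed in order.

As far as these compounds go, what iodo, an amine or a methoxy group would give at this carbon remains open.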